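The compounds below may be only part of what the source reports. "The series", "measured", "known", "first", "only" and "open" are said of these compounds alone.

Within the data shown here, compound 1 `CC(C)(O)C(CCC/C=C(\c1ccccc1)c1cccnc1)C(=O)O` is one of two compounds measured in an assay (Equus caballus) for inhibition of Thromboxane-A synthase (Homo sapiens), using microsomes; a lower number here means a stronger inhibitor, a higher number a weaker inhibitor. In this assay compound 1 gives 42 nM, the lower of the two numbers. Its companion, compound 2 `CC(C)CSC(CCC/C=C(\c1ccccc1)c1cccnc1)C(=O)O`, gives 110 nM in this assay; the step of a 2.6-fold higher number from compound 1 to compound 2 (0.42 log units; beyond the scatter) is modest but clear.

Compound 3 `CC(C)(CCCC/C=C(\c1ccccc1)c1cccnc1)C(=O)O` has not yet been measured. It differs from compound 1 in one place: 2-carboxy-2-methylpropyl in place of 1-carboxy-2-hydroxy-2-methylpropyl on a saturated chain carbon, three bonds along the chain from a double-bonded chain carbon. The hydroxy part of the leaving group is gone, and the carboxy is carried on a different carbon of the entering group.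

Among the measured compounds shown here, only one measured step bears on this change, and only loosely: from compound 1 to compound 2 the 1-hydroxy-1-methylethyl was also lost, and the number rose a 2.6-fold higher number from compound 1 to compound 2 (0.42 log units; beyond the scatter). That step alters the group on the carbon bearing the carboxy, while the present change also moves the carboxy itself, so the comparison is imperfect. A weakening of similar, modest size is the most reasonable expectation in this assay, expressed as a 2.6-fold higher number from compound 1 to compound 3 (0.42 log units; beyond the scatter). Compound 3 is therefore estimated at 110 nM, with a plausible range from 35 nM to 350 nM.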

Compound 3, half-maximal inhibitory concentration: 45 nM
The estimate for compound 3 lay 2.4-fold (0.39 log units) above the measured number, and the stated range covers the measured number.
By their numbers in this assay, from the lowest: compounds 1 and 3 (each within the scatter of the next); then compound 2.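

In this assay, replacing 1-carboxy-2-hydroxy-2-methylpropyl with 2-carboxy-2-methylpropyl gives a 1.1-fold higher number from compound 1 to compound 3 (0.03 log units; within the scatter) and so leaves the two compounds indistinguishable, even though the hydroxy is gone and the carboxy sits on a different carbon. The earlier step, a 2.6-fold higher number from compound 1 to compound 2 (0.42 log units; beyond the scatter), therefore does not mean that every replacement of the hydroxy-bearing group on the shared core comes with a higher number, and a group with one hydrogen-bond donor and one hydrogen-bond acceptor fewer can serve as well here. Nothing available explains why these two different groups give matching numbers.

The change removes the hydroxy and moves the carboxy in a single step, so the compounds shown leave open what each of these two alterations does alone, and the two effects may either both be small or offset each other. They also leave open whether a longer chain, or a primary amide in place of the carboxylic acid, would keep the number in this assay where compound 3 has it.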